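The source may hold more compounds than are shown below. What is called first, only, known or untested is meant among the compounds shown, and "the series" means these compounds.

Within the data shown here, in a functional assay on MCF7 cells (Homo sapiens) for cytotoxicity, read by MTT assay, with a stated time of 72 h (on this read-out higher numbers stand for weaker inhibition and lower numbers for stronger inhibition), two compounds with a shared core have numbers so far. Compound 1 `COc1ccc(/C=C2\CCC/C(=C\c3ccc(Cl)cc3)C2=O)cc1OC` gives 6300 nM, and compound 2 `COc1ccccc1/C=C1\CCC/C(=C\c2ccc(OC)c(OC)c2)C1=O` gives 8000 nM. Among the measured compounds shown here, these two values lie within the scatter of each other, so compound 2 stands level with the only other measured compound. Compound 3 `COc1ccc(/C=C2\CCC/C(=C\c3cccc(Cl)c3Cl)C2=O)cc1OC` has not yet been measured. It carries 2,3-dichlorophenyl in place of 2-methoxyphenyl on a double-bonded chain carbon bound to a double-bonded ring carbon. For the measured compounds named here, one measured step bears on this change, as it falls at the same place and also exchanges a chlorine-bearing group and 2-methoxyphenyl. That step, a 1.3-fold higher number from compound 1 to compound 2 (0.10 log units; within the scatter), stayed within the scatter. Going by the values given here, no measured compound has a second chlorine on this group, so the data cannot show what it adds. A shift beyond the scatter is therefore not expected in this assay, and no firm direction can be given. The expected change is a 1.2-fold lower number from compound 2 to compound 3 (0.09 log units; within the scatter), which is an estimate within the scatter. For compound 3 the estimated value is 6500 nM, with an expected range of 2500 nM to 16000 nM.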

Compound 3, half-maximal inhibitory concentration: 14300 nM
Estimate against measurement, compound 3: 2.2-fold (0.34 log units) below; the range from low to high includes it.
By their numbers in this assay, from the lowest: compounds 1, 2 and 3 (each within the scatter of the next, the first and the last beyond it).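

In this assay this position now gives its first step beyond the scatter: 2,3-dichlorophenyl in place of 4-chlorophenyl brings a 2.3-fold higher number from compound 1 to compound 3 (0.36 log units; beyond the scatter) and so a modest weakening of inhibition, while the earlier exchange at this place stayed within the scatter. The other new step, a 1.8-fold higher number from compound 2 to compound 3 (0.25 log units; within the scatter), also stays within the scatter, so 2,3-dichlorophenyl and 2-methoxyphenyl cannot be told apart here, and compound 2 stands level with both compound 1 and compound 3. Among these compounds, nothing on hand explains the one step that lies beyond the scatter.

Compound 1 and compound 3 differ both in the number of chlorines on this group and in where they sit, so the compounds shown cannot say which of the two matters, or whether the modest step would hold up with further chlorine-bearing groups. As far as these compounds go, what an amine, a carboxylic acid or a longer chain on a double-bonded chain carbon bound to a double-bonded ring carbon would do in this assay also remains open.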